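The compounds below may be only part of what the source reports. "The series", "measured", "known", "first", "only" and "open" are said of these compounds alone.

The measured compounds in an ADME assay on MT4 cells (Homo sapiens) for cytotoxicity, read by MTT assay; on this read-out higher numbers stand for lower toxicity in this test and lower numbers for higher toxicity in this test:
Compound 1 `Cc1ccccc1NC(=O)CSc1nncnc1-c1ccccc1Cl` gives 142000 nM.
Compound 2 `O=C(CSc1nncnc1-c1cccc2ccccc12)Nc1ccccc1` gives 154000 nM.
Compound 3 `Cc1ccc(NC(=O)CSc2nncnc2-c2cccc3ccccc23)c([N+](=O)[O-])c1` gives 147000 nM.

All three numbers sit close together. The gap from compound 1 to compound 2 and the gap from compound 1 to compound 3 both lie within the usual scatter of repeated measurements, so on this evidence compound 1 is neither more nor less toxic than the other two; it simply stands among them.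

Compound 4 `O=C(CSc1nncnc1-c1ccccc1Cl)Nc1ccccc1[N+](=O)[O-]` has not yet been measured. It differs from compound 1 in one place: nitro in place of methyl on an aromatic carbon. Among the measured compounds shown here, the one measured step that bears on this change is a 1.0-fold lower number from compound 2 to compound 3 (0.02 log units; within the scatter), where a nitro group is among what enters and the number hardly moves. Nothing else in the data separates a nitro from a methyl. On that basis the step of a 1.0-fold higher number from compound 1 to compound 4 (0.01 log units; within the scatter) is expected to stay within the scatter, with no direction favoured. Compound 4 is therefore estimated at 145000 nM, with a range from 70000 nM to 300000 nM.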

Compound 4, half-maximal cytotoxic concentration: 63000 nM
Compound 4: middle estimate off by 2.3-fold (0.36 log units), on the high side; measured number outside the range, below it.
By their numbers in this assay, from the lowest: compound 4; then compounds 1, 3 and 2 (each within the scatter of the next).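

In this assay, going from 2-methylphenyl to 2-nitrophenyl gives a 2.3-fold lower number from compound 1 to compound 4 (0.35 log units; beyond the scatter), so this one change, at a place ortho to a large group, shifts the result modestly towards higher toxicity in this test. The earlier nitro-bearing pair gave only a 1.0-fold lower number from compound 2 to compound 3 (0.02 log units; within the scatter), but that step also brought in a methyl and had a different parent, so a nitro group does not carry one fixed effect across these compounds. No measurement available here explains the shift.

It remains open whether the shift comes from gaining the nitro or from losing the methyl, since no compound with a hydrogen at this place is shown. Also open, as far as these compounds go, is how an amine, a methoxy group or a chlorine at the same place would compare.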